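Naphthalen-2-yl replacing furan-2-yl on the shared core

The source may hold more compounds than are shown below. What is called first, only, known or untested is meant among the compounds shown, and "the series" means these compounds.

In a functional assay for inhibition, with Homo sapiens as the target (on this read-out lower numbers stand for tighter binding and higher numbers for weaker binding), compound 3 `O=C(O)CC/C=C\CC1COC(c2ccco2)OC1c1cccnc1` gives 1260 nM, within the scatter of both compound 2 `O=C(O)CC/C=C\CC1COC(c2ccsc2)OC1c1cccnc1` at 1580 nM and compound 1 `O=C(O)CC/C=C\CC1COC(c2ccccc2Cl)OC1c1cccnc1` at 759 nM. Compound 4 `O=C(O)CC/C=C\CC1COC(c2ccc3ccccc3c2)OC1c1cccnc1` differs from compound 3 by the change (naphthalen-2-yl in place of furan-2-yl on a saturated ring carbon). Three measured steps at this carbon bear on it. Two stay within the scatter: a 1.7-fold higher number from compound 1 to compound 3 (0.22 log units; within the scatter) and a 1.3-fold lower number from compound 2 to compound 3 (0.10 log units; within the scatter). The third, a 2.1-fold higher number from compound 1 to compound 2 (0.32 log units; beyond the scatter), is modest and only just beyond it. Naphthalen-2-yl has no measured counterpart, and the 2-chlorophenyl of compound 1 at 759 nM is the nearest guide. The expected step is small and towards a lower number: a 1.7-fold lower number from compound 3 to compound 4 (0.23 log units; within the scatter). The estimate for compound 4 is 750 nM, with an expected range of 300 nM to 1700 nM.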

Compound 4, dissociation constant: 1780 nM
Beside the measured number, compound 4's estimate is 2.4-fold (0.38 log units) below it; measured number above the stated range.
By their numbers in this assay, from the lowest: compounds 1, 3, 2 and 4 (each within the scatter of the next, the first and the last beyond it).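

At this carbon between two ring oxygen atoms, two six-membered aromatic rings in naphthalen-2-yl read the same in this assay as a single five-membered aromatic ring, with a 1.4-fold higher number from compound 3 to compound 4 (0.15 log units; within the scatter) and a 1.1-fold higher number from compound 2 to compound 4 (0.05 log units; within the scatter). For the compounds shown here, the only step from compound 4 beyond the scatter is modest: a 2.3-fold higher number from compound 1 to compound 4 (0.37 log units; beyond the scatter). No measurement shown accounts for these steps.

Still open is whether an amine in place of the aromatic group at this carbon would move the number beyond the scatter of these compounds.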